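Carbamoyl for hydroxymethyl on the shared core

A few compounds are considered here, and "the series" means these few. Any claim that something is new, unique, unknown or untested is made for them only; others in the source may bear on it.

In a physicochemical assay for solubility, with a stated time of 4 h, at pH 2.0 (a lower number here means a less soluble compound, a higher number a more soluble compound), compound 2 `Cc1cc(CCC#N)cc(C)c1Oc1cc(Nc2ccc(C#N)cc2)c(N)cc1CO` gives 89.8 ug/mL. Compound 1 `CNC(=O)c1cc(N)c(Nc2ccc(C#N)cc2)cc1Oc1c(C)cc(CCC#N)cc1C` gives 44.7 ug/mL, which lies within the scatter of compound 2, so the two cannot be ranked. Compound 3 `COC(=O)c1cc(N)c(Nc2ccc(C#N)cc2)cc1Oc1c(C)cc(/C=C/C#N)cc1C` gives 1.75 ug/mL, far lower than either, but it differs from compound 2 in more than one place and offers no single-change comparison.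

Compound 4 `Cc1cc(CCC#N)cc(C)c1Oc1cc(Nc2ccc(C#N)cc2)c(N)cc1C(N)=O` is the next case: carbamoyl in place of hydroxymethyl on an aromatic carbon. Going by the values given here, one measured step bears on this carbamoyl in place of hydroxymethyl: a 2.0-fold higher number from compound 1 to compound 2 (0.30 log units; within the scatter), which exchanges methylcarbamoyl for hydroxymethyl on an aromatic carbon and stays within the scatter. Methylcarbamoyl is the closest measured group to carbamoyl, and no measurement of carbamoyl itself exists yet. Compound 4 is therefore expected to fall near compound 1, with a small move toward a lower number and nothing beyond the scatter. The estimated step is a 1.8-fold lower number from compound 2 to compound 4 (0.25 log units; within the scatter). For compound 4 the estimated value is 50 ug/mL, with an expected range of 18 ug/mL to 110 ug/mL.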

Compound 4, solubility: 9.11 ug/mL
The estimate for compound 4 lay 5.5-fold (0.74 log units) above the measured number; measured number outside the range, below it.
By their numbers in this assay, from the lowest: compound 3; then compound 4; then compounds 1 and 2 (each within the scatter of the next).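

In this assay the position on the aromatic carbon proves sensitive to a small change at the amide-type nitrogen, which the earlier pair could not show: the step with methylcarbamoyl was a 2.0-fold higher number from compound 1 to compound 2 (0.30 log units; within the scatter) and stayed within the scatter, whereas carbamoyl in place of hydroxymethyl gives a 9.9-fold lower number from compound 2 to compound 4 (0.99 log units; beyond the scatter) and lies beyond it. Hydrogen in place of methyl on the amide-type nitrogen gives a 4.9-fold lower number from compound 1 to compound 4 (0.69 log units; beyond the scatter) as well, so carbamoyl and methylcarbamoyl cannot be treated as interchangeable at this position. Nothing at hand gives a reason for either step.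

Open, going by these compounds, is whether a second methyl on the amide-type nitrogen, as in dimethylcarbamoyl, or a longer chain there such as ethylcarbamoyl, would stay with compound 1 or move away from it. Also open, on these data alone, is how a carboxylic acid or an aminomethyl group at this position would read against compound 2 and compound 4.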